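Shrinking the Ethyl to Methyl on a Shared Thiosugar Core

The source may report more compounds than this note shows. Statements on the series, on what has been measured and on what is new or still open speak of the compounds shown alone.

Three compounds have been measured in a functional assay on CCRF-HSB-2 cells (Homo sapiens) for antiproliferative activity; on this read-out higher numbers stand for weaker inhibition and lower numbers for stronger inhibition:
Compound 1, `O=c1[nH]c(=O)n([C@H]2S[C@H](CO)[C@@H](O)[C@@H]2O)cc1I`, gives > 100 ug/mL, a limit of the assay.
Compound 2, `CCc1cn([C@@H]2S[C@H](CO)[C@@H](O)[C@@H]2O)c(=O)[nH]c1=O`, gives > 100 ug/mL, a limit of the assay.
Compound 3, `CCc1cn([C@H]2S[C@H](CO)[C@@H](O)[C@@H]2O)c(=O)[nH]c1=O`, gives > 100 ug/mL, a limit of the assay.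

Compound 3 thus stands at the same limit as the other two, with no number to compare. The step that the two limits leave unreadable from compound 1 to compound 3 and the step that the two limits leave unreadable from compound 2 to compound 3 are both unreadable because of the limit of > 100 ug/mL in this assay, at which 3 of the 3 values shown sit, so neither gives a size. Compound 4, `Cc1cn([C@H]2S[C@H](CO)[C@@H](O)[C@@H]2O)c(=O)[nH]c1=O`, differs from compound 3 by hydrogen in place of methyl on a saturated chain carbon bound to an aromatic carbon. Going by the values given here, with every measured value sitting at the limit, no step bears on this change, and no shift beyond the scatter can be read. Compound 4 is estimated at 100 ug/mL, expected between 30 ug/mL and 300 ug/mL. The step of a number no higher from compound 3 to compound 4 (the limit leaves the size open) is therefore expected to be none, with the value most likely reported again as a limit.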

Compound 4, half-maximal inhibitory concentration: 42 ug/mL
Estimate against measurement, compound 4: 2.4-fold (0.38 log units) above; the range from low to high includes it.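

Going by these compounds alone, with methyl on the aromatic carbon, the shared core gives a real number for the first time in this assay and the group at this place clearly counts. Shortening ethyl to methyl gives an at least 2.3-fold lower number from compound 3 to compound 4 (0.37 log units; beyond the scatter) and methyl in place of iodo gives an at least 2.3-fold lower number from compound 1 to compound 4 (0.37 log units; beyond the scatter) on the same core. Both sizes are only minimums because compound 1 and compound 3 sit at a limit: the limit of > 100 ug/mL in this assay, at which 3 of the 4 values shown sit. On these data alone, what an amine or a fluoro group on that aromatic carbon would give stays open. So does whether methyl keeps this number with the configuration drawn in compound 2.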